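Benzyl chloromethyl series: removing the second ring chloro

The source may report more compounds than this note shows. Statements on the series, on what has been measured and on what is new or still open speak of the compounds shown alone.

Measured so far:
compound 1 `ClCc1ccc(Cn2cnc3c(Cl)ncnc32)cc1` — > 100000 nM
compound 2 `ClCc1ccccc1Cn1cnc2c(Cl)nc(Cl)nc21` — 5920 nM

Going by the values given here, compound 2 is the only member with a numerical reading: in a functional assay on UO-31 cells (Homo sapiens) for cytotoxicity, read by sulforhodamine B assay, with a stated time of 48 h (a lower number here means that less compound is tolerated, a higher number that more compound is tolerated), compound 2 gives 5920 nM. Among the compounds with values here, for compound 1 the assay returns only a limit, > 100000 nM; the limit of > 100000 nM in this assay, at which 1 of the 2 values shown sits, marks it as such, so no step between compound 1 and compound 2 can be sized. Compound 3 `ClCc1ccccc1Cn1cnc2c(Cl)ncnc21` is not yet measured. It differs from compound 2 by hydrogen in place of chloro on an aromatic carbon. Within the data shown here, compound 3 shares its core with compound 1 and its chloromethyl pattern with compound 2; no measured pair isolates either change. The expectation is a loss of cytotoxic potency beyond the scatter, given that compound 1, which also lacks this chloro, reaches only > 100000 nM. Compound 3 is therefore estimated at 40000 nM (range 10000 nM to 150000 nM), an expected step of a 6.8-fold higher number from compound 2 to compound 3 (0.83 log units; beyond the scatter).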

Compound 3, concentration lethal to 50% of the cells: 61700 nM
Compound 3: the middle estimate sits 1.5-fold (0.19 log units) below what was measured, within the range that was stated.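

In this assay, going by these compounds alone, the chloro on the aromatic carbon between two ring nitrogen atoms now has a size, with a 10-fold higher number from compound 2 to compound 3 (1.02 log units; beyond the scatter) for hydrogen in place of chloro, the first step that can be read. The chloromethyl pattern is the same in both compounds, and the pair differs only at this carbon, with one chlorine leaving and no ring, donor or acceptor count changing. The reading of compound 1 is a limit, and no step to it can be read: the limit of > 100000 nM in this assay, at which 1 of the 3 values shown sits.

Open, going by these compounds, is whether an amine, a methoxy group or a methyl group on this carbon would stay near the reading of compound 2 or move toward that of compound 3. Also open, on these data alone, is whether the same change gives a step of similar size with the chloromethyl pattern of compound 1.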